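Substituent swaps on the indole nitrogen of a 5-alpha-reductase series

This account rests on a few compounds, and the source may have more. Where it says the series, first, only, none or still open, it means among the compounds named here.

Three compounds sharing one core differ only in the group on the aromatic nitrogen. Compound 1 `CCCCCCn1ccc2cc(/C(C)=C/C(=O)Nc3ccccc3OCCCC(=O)O)ccc21` carries a hexyl group and in an assay on Prostate gland for inhibition of steroid 5-alpha-reductase (Rattus norvegicus) (a higher number here means a weaker inhibitor, a lower number a stronger inhibitor), compound 1 gives 77 nM. Compound 2 `CCCCCCCn1ccc2cc(/C(C)=C/C(=O)Nc3ccccc3OCCCC(=O)O)ccc21` lengthens that chain by one carbon, and in this assay compound 2 gives 120 nM. Compound 3 `CC(C)=CCn1ccc2cc(/C(C)=C/C(=O)Nc3ccccc3OCCCC(=O)O)ccc21` bears 3-methylbut-2-en-1-yl, and in this assay compound 3 gives 120 nM. Compound 3 therefore stands level with compound 2, the two together holding the highest numbers of the three, while compound 1 sits a 1.6-fold higher number from compound 1 to compound 3 (0.19 log units; within the scatter).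

Compound 4 `CCCC(C(C)C)n1ccc2cc(/C(C)=C/C(=O)Nc3ccccc3OCCCC(=O)O)ccc21` is not yet measured. It differs from compound 3 by 1-isopropylbutyl in place of 3-methylbut-2-en-1-yl on an aromatic nitrogen. Within the data shown here, the steps that bear on this change are a 1.6-fold higher number from compound 1 to compound 2 (0.19 log units; within the scatter), a 1.6-fold higher number from compound 1 to compound 3 (0.19 log units; within the scatter) and no change at the digits printed from compound 2 to compound 3 (within the scatter): every exchange of the group on the aromatic nitrogen so far has left the number within the scatter. Among the measured compounds shown here, no measured pair, however, replaces an unsaturated group with a saturated one of this shape, so that part of the change is untested. On the weight of the three steps he expects compound 4 to move by a 1.1-fold higher number from compound 3 to compound 4 (0.03 log units; within the scatter), that is, no change beyond the scatter. His estimate for compound 4 in this assay is 130 nM, with a range from 50 nM to 400 nM.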

Compound 4, half-maximal inhibitory concentration: 7.2 nM
Beside the measured number, compound 4's estimate is 18-fold (1.26 log units) above it; measured number outside the range, below it.
By their numbers in this assay, from the lowest: compound 4; then compounds 1, 2 and 3 (each within the scatter of the next).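

The group on the aromatic nitrogen had looked indifferent, but it is not: in this assay, 1-isopropylbutyl gives a 17-fold lower number from compound 3 to compound 4 (1.22 log units; beyond the scatter), and the same group gives a 17-fold lower number from compound 2 to compound 4 (1.22 log units; beyond the scatter) and an 11-fold lower number from compound 1 to compound 4 (1.03 log units; beyond the scatter). Among these compounds, since hexyl, heptyl and 3-methylbut-2-en-1-yl all lie within the scatter of one another, the earlier exchanges gave no sign of a step this large, and compound 4 is the strongest inhibitor of the four, its steps to all the others being printed as beyond the scatter. Nothing available here accounts for the size of this step.

With 1-isopropylbutyl the only group of its kind among these compounds, it remains open whether neighbouring groups such as 1-propylbutyl, 1-ethylpropyl, isopropyl or cyclohexyl would give a number like that of compound 4 or one like those of compounds 1, 2 and 3. Going by these compounds, it is also open whether the step would persist with the carboxylic acid of the shared core replaced, for example by a tetrazole or a primary amide, or with a longer chain carrying that acid.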